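Fluoro for Methoxy on a Sulfonamide Indole

The source may report more compounds than this note shows. Statements on the series, on what has been measured and on what is new or still open speak of the compounds shown alone.

Compound 1 `COc1ccc(S(=O)(=O)Nc2ccc3cc[nH]c3c2)cc1`: 45000 nM
Compound 2 `O=C(Nc1ccc2cc[nH]c2c1)c1ccc(F)cc1`: 35100 nM

In a functional assay on T47D cells (Homo sapiens) for antiproliferative activity, read by MTT assay, with a stated time of 24 h (a lower number here means a stronger inhibitor, a higher number a weaker inhibitor), compound 1 gives 45000 nM, the higher of the two numbers shown, though the gap to compound 2 lies within the usual scatter, so the two cannot be separated. Compound 3 `O=S(=O)(Nc1ccc2cc[nH]c2c1)c1ccc(F)cc1` differs from compound 1 by fluoro in place of methoxy on an aromatic carbon. For the measured compounds named here, no step between measured compounds speaks to this exchange, so the expectation rests on compound 1 alone, and the step from compound 1 to compound 3 is expected to stay within the scatter, with no clear direction. Compound 3 is accordingly expected to give about 38000 nM in this assay, between 13000 nM and 110000 nM, an expected step of a 1.2-fold lower number from compound 1 to compound 3 (0.07 log units; within the scatter).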

Compound 3, half-maximal inhibitory concentration: 33000 nM
Compound 3: the middle estimate sits 1.2-fold (0.06 log units) above what was measured; the measured number falls inside the stated range.
By their numbers in this assay, from the lowest: compounds 3, 2 and 1 (each within the scatter of the next).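

In this assay, fluoro in place of methoxy on this aromatic carbon gives a 1.4-fold lower number from compound 1 to compound 3 (0.13 log units; within the scatter), the first step measured at this position. Compound 1 and compound 3 cannot be separated, so this exchange shows no clear effect on the number here. Nothing available bears on the reason for this result. As far as these compounds go, it remains open whether an amine, a carboxylic acid or a trifluoromethyl group at this position would move the number beyond the scatter. From the compounds shown here alone, the effect of methoxy in place of fluoro on compound 2 also remains open.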